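Imidazoline for isopropylamidine on a second core

The source may hold more compounds than are shown below. What is called first, only, known or untested is meant among the compounds shown, and "the series" means these compounds.

Compound 1 `CC(C)NC(=N)c1ccc2oc(-c3cccc(OCCCCCCOc4ccccc4)c3)cc2c1` and compound 2 `c1ccc(OCCCCCCOc2cccc(-c3cc4cc(C5=NCCN5)ccc4o3)c2)cc1` share one core, and compound 3 `CC(C)NC(=N)c1ccc2oc(-c3ccc(OCCCCCOc4ccccc4)cc3)cc2c1` and compound 4 `c1ccc(OCCCCCOc2ccc(-c3cc4cc(C5=NCCN5)ccc4o3)cc2)cc1` share another; the difference between the two cores is not broken down here. In an ADME assay on L6 cells (Rattus norvegicus) for cytotoxicity, read by resazurin assay, with a stated time of 70 h (on this read-out higher numbers stand for weaker inhibition and lower numbers for stronger inhibition), compound 1 gives 7400 nM and compound 2 gives 2500 nM; the change a group of 5 heavy atoms (3 carbon, 2 nitrogen; one five-membered non-aromatic ring with 2 hetero atoms) in place of a group of 6 heavy atoms (4 carbon, 2 nitrogen; no ring), on an aromatic carbon yields a 3.0-fold lower number from compound 1 to compound 2 (0.47 log units; beyond the scatter). In this assay compound 3 gives 20500 nM, the highest of the three measured numbers. Compound 4 carries the same change on its own core, (a group of 5 heavy atoms (3 carbon, 2 nitrogen; one five-membered non-aromatic ring with 2 hetero atoms) in place of a group of 6 heavy atoms (4 carbon, 2 nitrogen; no ring), on an aromatic carbon). Within the data shown here, for compound 4 the step is expected to be a 3.0-fold lower number from compound 3 to compound 4 (0.48 log units; beyond the scatter), resting on the single measured instance of this change, which gave a 3.0-fold lower number from compound 1 to compound 2 (0.47 log units; beyond the scatter). On that basis compound 4 is estimated at 6800 nM in this assay, with a plausible range from 3400 nM to 13600 nM.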

Compound 4, half-maximal inhibitory concentration: 900 nM
Beside the measured number, compound 4's estimate is 7.6-fold (0.88 log units) above it; the whole stated range lies above it.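

In this assay the change gives a 23-fold lower number from compound 3 to compound 4 (1.36 log units; beyond the scatter), the same direction as on the core of compound 1. The size of the step did not carry over from one core to the other: the same change on two cores in this assay, a 3.0-fold lower number (0.47 log units; beyond the scatter) from compound 1 to compound 2 and a 23-fold lower number (1.36 log units; beyond the scatter) from compound 3 to compound 4, 7.7-fold (0.89 log units) apart, beyond the scatter of two such steps Across these two pairs the direction held, but a step measured on one core did not fix its size on the other, and two pairs cannot show what sets the gap.

The compounds shown leave open which of the differences between the two cores goes with the larger step. As far as these compounds go, how the step would run on a core with a longer chain, or with a simple amine in place of either group, also stays open.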